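Compound 4 in the cytotoxicity series

A few compounds are considered here, and "the series" means these few. Any claim that something is new, unique, unknown or untested is made for them only; others in the source may bear on it.

Measured so far in a toxicity assay on HepG2 2.2.15 cells (Homo sapiens) for cytotoxicity, read by CellTiter-Glo; on this read-out lower numbers stand for higher toxicity in this test and higher numbers for lower toxicity in this test:
- compound 1 `N#CC1CC(=O)N(c2cnn3c2CN(C(=O)Nc2cc(F)c(F)c(F)c2)C(C2CC2)C3)C1`: > 200000 nM (a limit of the assay)
- compound 2 `O=C1CC(c2cnco2)CN1c1cnn2c1CN(C(=O)Nc1cc(F)c(F)c(F)c1)C(C1CC1)C2`: 139000 nM
- compound 3 `O=C1c2ccccc2CN1c1cnn2c1CN(C(=O)Nc1cc(F)c(F)c(F)c1)C(C1CC1)C2`: 38500 nM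

Compound 3, at 38500 nM, has the lowest number in the series. Among the compounds with values here, compound 2 is the only other compound with a true number, and compound 1 has only a limit.

Compound 4 `O=C1CC(c2ncco2)CN1c1cnn2c1CN(C(=O)Nc1cc(F)c(F)c(F)c1)C(C1CC1)C2` has not yet been measured. It is reached from compound 3 by a group of 11 heavy atoms (7 carbon, 2 nitrogen, 2 oxygen; one five-membered non-aromatic ring with 1 hetero atom, one five-membered aromatic ring with 2 hetero atoms) in place of a group of 10 heavy atoms (8 carbon, 1 nitrogen, 1 oxygen; one five-membered non-aromatic ring with 1 hetero atom, one six-membered aromatic ring of carbon only), on an aromatic carbon. The entering 4-(1,3-oxazol-2-yl)-2-oxopyrrolidin-1-yl group has the same composition as the group that compound 2 gives up in a 3.6-fold lower number from compound 2 to compound 3 (0.56 log units; beyond the scatter), although compound 2 carries 1,3-oxazol-5-yl. That step is the closest guide, read in reverse. an at least 5.1-fold lower number from compound 1 to compound 3 (0.71 log units; beyond the scatter) points the same way, while an at least 1.4-fold lower number from compound 1 to compound 2 (0.15 log units; that floor lies within the scatter) has a floor within the scatter and sets no size. Compound 2, at 139000 nM, therefore serves as the anchor, though this rests on very few compounds.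

In this assay, the expected change is a 3.1-fold higher number from compound 3 to compound 4 (0.49 log units; beyond the scatter), a modest move towards a higher number and lower toxicity in this test. For compound 4 the estimated value is 120000 nM, with an expected range from 55000 nM to 200000 nM.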

Compound 4, half-maximal cytotoxic concentration: > 200000 nM
Compound 4: only a limit was reported (the forecaster's own chance of this, stated with the estimate: 25%); middle value at least 1.6-fold (0.22 log units) away from the limit.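

With the 4-(1,3-oxazol-2-yl)-2-oxopyrrolidin-1-yl group on the aromatic carbon, this assay shows an at least 5.1-fold higher number from compound 3 to compound 4 (0.71 log units; beyond the scatter), so a second oxazole-bearing oxopyrrolidinyl group now stands clear of compound 3 beyond the scatter. Placing 1,3-oxazol-2-yl instead of 1,3-oxazol-5-yl on the saturated ring carbon gives an at least 1.4-fold higher number from compound 2 to compound 4 (0.15 log units; that floor lies within the scatter), a floor within the scatter, so this change is not shown to matter, and the steps between limits cannot be read. Compound 4 reports only a limit of the assay, and the read-out now ends there for part of the series: the limit of > 200000 nM in this assay, at which 2 of the 4 values shown sit.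

As far as these compounds go, how far compound 1 and compound 4 lie past that limit stays open, so they cannot be ordered against each other, and any true size of the change from compound 2 to compound 4 remains unknown. Also open, from the compounds shown here alone, is whether an amine, a carboxylic acid or a phenyl group on the saturated ring carbon would leave the number at the limit or bring it nearer to that of compound 3.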